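Working notes on the series, compound 3 to compound 4

The source may report more compounds than this note shows. Statements on the series, on what has been measured and on what is new or still open speak of the compounds shown alone.

The series shares one core, and compound 1 `COc1cc(N(Cc2ccccc2)C(=O)CSc2nc3ccccc3s2)cc(OC)c1OC` is its plainest member. In a functional assay on MGC-803 cells (Homo sapiens) for antiproliferative activity, read by MTT assay, with a stated time of 48 h (a higher number here means a weaker inhibitor, a lower number a stronger inhibitor), compound 1 gives 44300 nM. Compound 2 `COc1cc(N(Cc2ccc(C)cc2)C(=O)CSc2nc3ccccc3s2)cc(OC)c1OC` carries a methyl in place of hydrogen on an aromatic carbon and gives 54200 nM; the step of a 1.2-fold higher number from compound 1 to compound 2 (0.09 log units; within the scatter) says nothing beyond the scatter. Compound 3 `COc1ccc(CN(C(=O)CSc2nc3ccccc3s2)c2cc(OC)c(OC)c(OC)c2)cc1N` gives 84 nM, the lowest of the three numbers, with steps a 530-fold lower number from compound 1 to compound 3 (2.72 log units; beyond the scatter) and a 650-fold lower number from compound 2 to compound 3 (2.81 log units; beyond the scatter) both far beyond the scatter. Nothing here separates what the amino and what the methoxy each contribute to that gain.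

Compound 4 `COc1ccc(CN(C(=O)CSc2nc3ccccc3s2)c2cc(OC)c(OC)c(OC)c2)cc1C(F)(F)F` differs from compound 3 in one place: trifluoromethyl in place of amino on an aromatic carbon. Going by the values given here, no measured step touches this exchange. The one aromatic substitution measured, a 1.2-fold higher number from compound 1 to compound 2 (0.09 log units; within the scatter), was small, but that swap did not touch a group that accompanied a large gain, whereas here the amino that entered with compound 3 leaves. The expectation is therefore a higher number in this assay for compound 4, of uncertain size, estimated as the step of an 18-fold higher number from compound 3 to compound 4 (1.25 log units; beyond the scatter). Compound 4 is expected to give 1500 nM, within a range from 150 nM to 15000 nM.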

Compound 4, half-maximal inhibitory concentration: 25200 nM
Compound 4: the middle estimate sits 17-fold (1.23 log units) below what was measured; the whole stated range lies below it.
By their numbers in this assay, from the lowest: compound 3; then compounds 4, 1 and 2 (each within the scatter of the next, the first and the last beyond it).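

The exchange at this aromatic carbon, ortho to a methoxy group, is now isolated: in this assay the methoxy stays, and replacing amino with trifluoromethyl gives a 300-fold higher number from compound 3 to compound 4 (2.48 log units; beyond the scatter). The methoxy with trifluoromethyl alongside it therefore does not retain the gain seen with compound 3, and a 1.8-fold lower number from compound 1 to compound 4 (0.25 log units; within the scatter) leaves 4-methoxy-3-(trifluoromethyl)phenyl not separated from plain phenyl. Against 4-methylphenyl the same group gives only a 2.2-fold lower number from compound 2 to compound 4 (0.33 log units; beyond the scatter), a modest difference. In this set the large gain appears only with 3-amino-4-methoxyphenyl. No measurement here bears on why this exchange has so large an effect.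

The compounds shown do not tell whether the gain requires the amino itself or would persist with a hydroxy, a methylamino or an acetamido group on this carbon. They also leave open whether the amino needs the methoxy, which 3-aminophenyl would address, and whether a hydrogen on this carbon would read like trifluoromethyl.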